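Methoxycarbonyl for Fluoro on Two Related Urea Cores

This account rests on a few compounds, and the source may have more. Where it says the series, first, only, none or still open, it means among the compounds named here.

Compound 1, `Cc1cc(NC(=O)Nc2ccc(F)cc2)c2ccccc2n1`: in an ADME assay on HepG2 cells (Homo sapiens) for cytotoxicity, with a stated time of 72 h (a lower number here means that less compound is needed, a higher number that more compound is needed for the effect), compound 1 gives > 25000 nM, which is a limit of the assay and not a number.
Compound 2, `Cc1cc(NC(=O)Nc2cccc(F)c2)c2ccccc2n1`: compound 2 gives > 25000 nM, again a limit of the assay.
Compound 3, `COC(=O)c1ccc(NC(=O)Nc2cc(C)nc3ccccc23)cc1`: compound 3 gives 20000 nM.

Compounds 1 and 2 are built from the same atoms joined differently; the difference between the two cores is 3-fluorophenyl in place of 4-fluorophenyl on an amide-type nitrogen. The step between them is a step that the two limits leave unreadable from compound 1 to compound 2. Compound 3 arises from compound 1 through (methoxycarbonyl in place of fluoro on an aromatic carbon), and the step is an at least 1.2-fold lower number from compound 1 to compound 3 (0.09 log units; that floor lies within the scatter), so no real change can be read from it. Two of the three values sit at the limit of > 25000 nM in this assay, at which 2 of the 3 values shown sit.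

Compound 4, `COC(=O)c1cccc(NC(=O)Nc2cc(C)nc3ccccc23)c1`, is not yet measured. It arises from compound 2 through (methoxycarbonyl in place of fluoro on an aromatic carbon), the same kind of change as from compound 1 to compound 3, made twice among the compounds shown; the place differs only in being meta to a large group here and para to a large group there. In this assay the expected step is an at least 1.1-fold lower number from compound 2 to compound 4 (0.05 log units; that floor lies within the scatter), resting on the earlier at least 1.2-fold lower number from compound 1 to compound 3 (0.09 log units; that floor lies within the scatter), which stays within the scatter. Compound 4 is therefore estimated at 22000 nM, expected between 9000 nM and 50000 nM, with a fair chance that only a limit is reported.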

Compound 4, half-maximal effective concentration: 23000 nM
Compound 4: middle estimate off by 1.0-fold (0.02 log units), on the low side, and the stated range covers the measured number.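

In this assay, methoxycarbonyl in place of fluoro on the core of compound 2 gives an at least 1.0-fold lower number from compound 2 to compound 4 (0.03 log units; that floor lies within the scatter), so no real change can be read from this step. Set beside the same change on the core of compound 1, this step cannot settle whether the change carries over with the same size, and the comparison stays open: the same change on two cores in this assay, an at least 1.2-fold lower number (0.09 log units; that floor lies within the scatter) from compound 1 to compound 3 and an at least 1.0-fold lower number (0.03 log units; that floor lies within the scatter) from compound 2 to compound 4; the limit leaves it open whether they differ

This does not show that the change has no effect on either core, because both fluoro compounds stand at a limit of the assay rather than at a number: the limit of > 25000 nM in this assay, at which 2 of the 4 values shown sit.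

From the compounds shown here alone, the true values of compound 1 and compound 2 therefore stay open, and so does the size of the change on each core. The compounds shown also leave open how an amine or a carboxylic acid would read in this position on the same two cores, since only fluoro and methoxycarbonyl appear there.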